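This account rests on a few compounds, and the source may have more. Where it says the series, first, only, none or still open, it means among the compounds named here.

Compound 1 `CC1(c2ccccc2)CC(=O)N(CC(=O)N2CCN(c3ccccc3)CC2)C1=O` gives 100 mg/kg in a functional assay on the whole organism (strain CD-1) with Mus musculus as the target, with a stated time of 0.5 h; on this read-out higher numbers stand for an effect only at larger amounts of compound and lower numbers for an effect already at smaller amounts. Compound 2 `COc1ccccc1N1CCN(C(=O)CN2C(=O)CC(C)(c3ccccc3)C2=O)CC1` is reported in this assay as "not active" (no number reported), so no single number places compound 2 beside compound 1 on this read-out. Compound 3 `CC1(c2ccccc2)CC(=O)N(CC(=O)N2CCN(c3cccc(C(F)(F)F)c3)CC2)C1=O` carries 3-(trifluoromethyl)phenyl in place of 2-methoxyphenyl on an amine nitrogen in a ring. Among the compounds with values here, with no number for compound 2, no step to compound 3 can be sized in this assay; an effect at a measurable dose is expected for compound 3, which would be a move toward smaller doses relative to what compound 2 showed. Compound 3 is expected to give 100 mg/kg in this assay, within a range from 30 mg/kg to 300 mg/kg.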

Compound 3, minimum effective dose: "not active" (no number reported)
Compound 3 has no reported number here; the estimate stays without a comparison.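

Within the data shown here, compound 3, like compound 2, is reported without a number in this assay, so no step between compound 2 and compound 3 can be read. The compounds shown leave open how far either lies from compound 1 on this read-out. Nothing here offers an explanation for this result.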